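Triazole series: phenoxy to trifluoromethoxy exchange

The source may report more compounds than this note shows. Statements on the series, on what has been measured and on what is new or still open speak of the compounds shown alone.

Measured in a functional assay on MDA-MB-231 cells (Homo sapiens) for cytotoxicity, read by MTT assay; on this read-out lower numbers stand for stronger inhibition and higher numbers for weaker inhibition:
compound 1 `COc1ccc(-c2cn(-c3ccc(OC(F)(F)F)cc3)nn2)cc1O` gives > 10000 nM, a limit of the assay.
compound 2 `COc1cc(OC)cc(-c2cn(-c3ccc(Oc4ccccc4)cc3)nn2)c1` gives > 10000 nM, a limit of the assay.
compound 3 `COc1ccc(-c2cn(-c3ccc(Oc4ccccc4)cc3)nn2)cc1O` gives > 10000 nM, a limit of the assay.

All three values in this assay sit at the limit of > 10000 nM in this assay, at which 3 of the 3 values shown sit. From compound 3 to compound 1 the change is trifluoromethyl in place of phenyl on an oxygen on an aromatic ring. The step that the two limits leave unreadable from compound 3 to compound 1 is unreadable; both of its ends are limits.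

Compound 4 `COc1cc(OC)cc(-c2cn(-c3ccc(OC(F)(F)F)cc3)nn2)c1` is not yet measured in this assay. From compound 2 it differs by trifluoromethyl in place of phenyl on an oxygen on an aromatic ring, the same change as from compound 3 to compound 1, at the same place. The difference between the cores of compound 2 and compound 3 is not broken down here.

The step from compound 2 to compound 4 is expected to be a step that the limit leaves unreadable from compound 2 to compound 4, resting on the fact that all three measured values sit at the limit of > 10000 nM in this assay, at which 3 of the 3 values shown sit. Compound 4 is expected to give 15000 nM, most likely again a limit, in the range 7000 nM to 50000 nM.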

Compound 4, half-maximal inhibitory concentration: > 1000 nM
Compound 4: only a limit was reported; the forecaster's own chance of this, stated with the estimate: 85%; the middle value lies beyond the limit too.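

The step between compound 2 and compound 4 cannot be read: in this assay, both of its ends are limits of the assay. The compounds shown leave open whether phenoxy to trifluoromethoxy changes the read-out on either core.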